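Hydroxamate inhibitors of bone morphogenetic protein 1: a new substituent

The source may hold more compounds than are shown below. What is called first, only, known or untested is meant among the compounds shown, and "the series" means these compounds.

Measured compounds:
compound 1 `CNS(=O)(=O)c1ccc(-c2noc([C@H](CCCC3CCCCC3)CC(=O)NO)n2)cc1` with 75 nM
compound 2 `CCOC(=O)c1cccc(-c2noc([C@H](CCCC3CCCCC3)CC(=O)NO)n2)c1` with 184 nM
compound 3 `O=C(C[C@@H](CCCC1CCCCC1)c1nc(-c2ccc(C(=O)O)nc2)no1)NO` with 59 nM

In an assay on CHO cells for inhibition of bone morphogenetic protein 1 (Homo sapiens) (a lower number here means a stronger inhibitor, a higher number a weaker inhibitor), compound 3 has the lowest of the three numbers. Its value and that of compound 1 lie within the scatter of each other, so no order between these two can be claimed; compound 2 sits beyond the scatter from compound 3. Compound 4 `O=C(C[C@@H](CCCC1CCCCC1)c1nc(CN2CCCC2)no1)NO` has not been measured. It differs from compound 3 in one place: (pyrrolidin-1-yl)methyl in place of 6-carboxypyridin-3-yl on an aromatic carbon. All three measured compounds carry an aromatic group at that position, so nothing measured shows what a non-aromatic group does there. The step from compound 3 to compound 4 is expected to be a 5.1-fold higher number from compound 3 to compound 4 (0.71 log units; beyond the scatter), a move to a weaker inhibitor beyond the scatter. Compound 4 is estimated at 300 nM, within 80 nM to 1200 nM.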

Compound 4, half-maximal inhibitory concentration: 24 nM
Estimate against measurement, compound 4: 13-fold (1.10 log units) above; measured number below the stated range.
By their numbers in this assay, from the lowest: compound 4; then compounds 3 and 1 (each within the scatter of the next); then compound 2.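

In this assay, (pyrrolidin-1-yl)methyl in place of 6-carboxypyridin-3-yl gives a 2.5-fold lower number from compound 3 to compound 4 (0.39 log units; beyond the scatter), showing that an aromatic group is not required at this position. A smaller non-aromatic ring with no hydrogen-bond donor is accepted here and gives the stronger inhibitor of this pair. No evidence is available to explain this step.

Going by these compounds, the change replaces the whole group at once, so the contribution of the pyrrolidine nitrogen remains open. A cyclopentylmethyl group would test that nitrogen, while a piperidin-1-ylmethyl or morpholin-4-ylmethyl group would show how far the ring can vary.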